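A Chloro Step at the Top of the Range

The source may report more compounds than this note shows. Statements on the series, on what has been measured and on what is new or still open speak of the compounds shown alone.

Measured in a functional assay on RD cells (Homo sapiens) for inhibition, read by luminescence and ATP content, with a stated time of 72 h; on this read-out higher numbers stand for lower toxicity in this test and lower numbers for higher toxicity in this test:
Compound 1 `Cc1nc(-c2cnc3ccc(-c4ccc(N)cc4)cc3c2)no1`: > 2500 nM
Compound 2 `Cc1ccc(-c2ccc3ncc(-c4noc(C(F)(F)F)n4)cc3c2)cc1`: > 22200 nM
Compound 3 `FC(F)(F)c1nc(-c2cnc3ccc(-c4ccccc4)cc3c2)no1`: > 22200 nM

All three entries are limits, not numbers. Compound 3 gives > 22200 nM, which is a limit. It stands at the limit of > 22200 nM in this assay, at which 2 of the 3 values shown sit, while compound 1 stands at the limit of > 2500 nM in this assay, at which 1 of the 3 values shown sits. Compound 4 `FC(F)(F)c1nc(-c2cnc3ccc(-c4ccc(Cl)cc4)cc3c2)no1` has chloro in place of hydrogen on an aromatic carbon, phenyl becoming 4-chlorophenyl: chloro in place of hydrogen on an aromatic carbon. Among the measured compounds shown here, the only measured step, hydrogen in place of methyl on an aromatic carbon, is a step that the two limits leave unreadable from compound 2 to compound 3, so it offers no size to carry over. No step beyond the scatter is therefore expected in this assay, in either direction. The expected step is a number no higher from compound 3 to compound 4 (the limit leaves the size open). For compound 4 the estimate is 22200 nM, expected to fall between 9000 nM and 50000 nM.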

Compound 4, half-maximal cytotoxic concentration: > 200000 nM
Compound 4 ended at the assay's limit; the forecaster's own chance of this, stated with the estimate: 75%; middle value at least 9.0-fold (0.95 log units) from the limit.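

Among the compounds shown here, compound 4 gives > 200000 nM, which is a limit, as are the values of compound 2 and compound 3, so no step among the three can be read. What the compounds shown leave open is where any true half-maximal cytotoxic concentration lies.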